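The compounds below may be only part of what the source reports. "The series", "measured", "known", "first", "only" and "open" are said of these compounds alone.

Going by the values given here, compound 3 `Cc1ccc2nc(N)nc(O)c2c1` gives 4.44 in an assay for inhibition of Dihydrofolate reductase (Homo sapiens) (on this read-out lower numbers stand for lower potency and higher numbers for higher potency (the scale is a negative logarithm)), the lowest of the three numbers measured so far. Compound 1 `Nc1nc(N)c2cc(C=O)ccc2n1` gives 5 and compound 2 `Nc1nc(N)c2cc(Cl)ccc2n1` gives 5.4; both carry two amino groups on the shared core and both stand above compound 3 beyond the scatter. Compound 4 `Cc1ccc2nc(N)nc(N)c2c1` differs from compound 3 in one place: amino in place of hydroxy on an aromatic carbon. Among the compounds with values here, no measured step exchanges hydroxy for amino; the only measured step, a number 0.40 log units higher from compound 1 to compound 2 (beyond the scatter), concerns another group and bears on this change only indirectly. Because compound 1 gives 5 and compound 2 gives 5.4, compound 4 is expected to move toward those numbers, a step of a number 0.86 log units higher from compound 3 to compound 4 (beyond the scatter). Compound 4 is therefore estimated at 5.3, within 4.6 to 6.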

Compound 4, logarithm of the reciprocal of the active concentration, log(1/C): 5.66
Estimate against measurement, compound 4: 0.36 log units below; low and high end bracket the measured number.
By their numbers in this assay, from the lowest: compound 3; then compound 1; then compounds 2 and 4 (each within the scatter of the next).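

In this assay, amino in place of hydroxy on this aromatic carbon, next to the ring nitrogen, gives a number 1.22 log units higher from compound 3 to compound 4 (beyond the scatter) as the largest step seen so far, so this place responds strongly to the exchange. With two amino groups on the shared core, the change to methyl reads a number 0.26 log units higher from compound 2 to compound 4 (within the scatter) from chloro and a number 0.66 log units higher from compound 1 to compound 4 (beyond the scatter) from formyl. Going by these compounds, whether a methylamino or methoxy group on this carbon would give a number nearer that of amino or of hydroxy stays open. Nothing available accounts for the size of the step.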